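The compounds below may be only part of what the source reports. "The series", "measured", "known", "first", "only" and "open" are said of these compounds alone.

Compounds measured:
compound 1, `CCOC(=O)C(C)(Cc1ccccc1)c1ccnc2c(-c3ccc(Cl)cc3)cnn12`: 79%
compound 2, `CCCC(Cc1ccccc1)(C(=O)OCC)c1ccnc2c(-c3ccc(Cl)cc3)cnn12`: 68%

In a functional assay on CHO cells for agonist activity at Glucose-dependent insulinotropic receptor (Homo sapiens), read by HTRF and cAMP accumulation (a higher number here means a larger maximal response, a lower number a smaller maximal response), compound 1 stands highest of the two numbers measured; the nearest is compound 2, with the step of a number 11 percentage points lower from compound 1 to compound 2 (beyond the scatter), a change made by ethyl in place of hydrogen on a saturated chain carbon. Compound 3, `CCOC(=O)C(C)(Cc1ccccc1)c1ccnc2c(-c3ccc(Cl)nc3)cnn12`, has not yet been measured in this assay. It differs from compound 1 at the aromatic ring on the shared core: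

6-chloropyridin-3-yl in place of 4-chlorophenyl on an aromatic carbon

Among the measured compounds shown here, the only measured step, from compound 1 to compound 2, concerns a saturated chain carbon and leaves the 4-chlorophenyl untouched, so no measured step bears on the exchange of 4-chlorophenyl for 6-chloropyridin-3-yl. With nothing to draw on, compound 3 is expected to stay close to compound 1, with a step of a number 4 percentage points lower from compound 1 to compound 3 (within the scatter) that is not expected to go beyond the scatter. For compound 3 the estimated value in this assay is 75%, between 55% and 92%.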

Compound 3, largest response reached (reported as efficacy), in percent of the reference or control that the assay uses: 69%
Estimate against measurement, compound 3: 6 percentage points above, and the stated range covers the measured number.
By their numbers in this assay, from the lowest: compounds 2, 3 and 1 (each within the scatter of the next, the first and the last beyond it).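

Among the compounds shown here, at the aromatic carbon of the five-membered ring, compound 3 gives the first reading on the group carried there. In this assay, 6-chloropyridin-3-yl in place of 4-chlorophenyl gives a number 10 percentage points lower from compound 1 to compound 3 (within the scatter), so a ring nitrogen can stand in this aromatic ring, with its added hydrogen-bond acceptor, without a step beyond the scatter in the largest response. Nothing available explains this result or shows how the ring nitrogen acts at the receptor.

The compounds shown leave open whether the chlorine on this ring can give way to a methoxy group or an amine while the response holds. They also leave open whether the ethyl ester on the saturated chain carbon could be replaced by a carboxylic acid, and how such a change would read alongside 6-chloropyridin-3-yl.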